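Methyl on the ring alcohol carbon of a lactone

This account rests on a few compounds, and the source may have more. Where it says the series, first, only, none or still open, it means among the compounds named here.

All four compounds carry the same dichlorophenyl vinyl side chain on a six-membered lactone. Compound 1 `CC1=CC(=O)OC(/C=C/c2ccc(Cl)cc2Cl)C1`, which has a double bond in the ring and no hydroxyl, gives 3% in an assay for inhibition of 3-hydroxy-3-methylglutaryl-coenzyme A reductase (Rattus norvegicus), tested at 10 ug/mL; on this read-out higher numbers stand for a stronger effect at the one concentration tested and lower numbers for a weaker effect. Compound 2 `O=C1C[C@@H](O)C[C@@H](/C=C/c2ccc(Cl)cc2Cl)O1` gives 27% in this assay, the higher of the two numbers, with compound 1 lying lower by a gap beyond the usual scatter. Compound 3 `O=C1C[C@H](O)C[C@@H](/C=C/c2ccc(Cl)cc2Cl)O1` gives 64%; 72% (2 entries) in this assay; it differs from compound 2 only in the configuration as drawn (the fact that compounds 2 and 3 differ only in the configuration as drawn), and its several entries agree with each other (the several entries of compound 3 in this assay, 64%; 72% (2 entries)).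

Compound 4 `C[C@]1(O)CC(=O)O[C@H](/C=C/c2ccc(Cl)cc2Cl)C1` is compound 2 with one change: methyl in place of hydrogen on a saturated ring carbon. Among the compounds with values here, no measured pair here shows what such a methyl does. The step is expected to be small, downward if anything, a number 7 percentage points lower from compound 2 to compound 4 (within the scatter), staying within or near the scatter. Compound 4 is therefore estimated at 20% in this assay, most likely between 5% and 45%.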

Compound 4, a percentage reported as inhibition, at one concentration (the size of the read-out at that concentration, not a potency): 61%
Beside the measured number, compound 4's estimate is 41 percentage points below it, and the stated range ends below it.
By their numbers in this assay, from the lowest: compound 1; then compound 2; then compound 4.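

At the ring carbon that carries the hydroxyl, one added methyl turns out not to be a minor change in this assay: the read-out gives a number 34 percentage points higher from compound 2 to compound 4 (beyond the scatter). This carbon can therefore hold an extra group alongside its hydroxyl with no loss of effect, and in this pair the effect rises. The earlier compounds had shown only that the spatial arrangement of the ring matters, since two structures with different numbers are otherwise the same: the fact that compounds 2 and 3 differ only in the configuration as drawn

The compounds shown leave open how an ethyl group or a longer chain on this carbon would read, and whether a methyl would give the same rise in the other configuration as drawn. They also offer no explanation for the rise itself, which stands here as a single pair.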